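Changing the amide cap on a shared core

This account rests on a few compounds, and the source may have more. Where it says the series, first, only, none or still open, it means among the compounds named here.

Compound 1, `C=CC(=O)Nc1cccc(-c2nc3ccccc3s2)c1`: > 25000 nM
Compound 2, `O=C(Nc1cccc(-c2nc3ccccc3s2)c1)c1ccc(Cl)nc1Cl`: > 25000 nM

Both values in an ADME assay on Raji cells (Homo sapiens) for inhibition, with a stated time of 72 h (a higher number here means that more compound is needed for the effect, a lower number that less compound is needed), are limits of the assay rather than numbers. Compound 1 gives a limit of > 25000 nM. Compound 2 likewise gives a limit of > 25000 nM. The step that the two limits leave unreadable from compound 1 to compound 2 therefore cannot be read in size or direction. Within the data shown here, compound 2 thus stands at the limit, and so does the one further value shown: the limit of > 25000 nM in this assay, at which 2 of the 2 values shown sit.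

Compound 3, `O=C(Nc1cccc(-c2nc3ccccc3s2)c1)c1ccncc1Cl`, differs from compound 2 by 3-chloropyridin-4-yl in place of 2,6-dichloropyridin-3-yl on a carbonyl carbon. Among the measured compounds shown here, no measured step bears directly on this change; the only measured step, a step that the two limits leave unreadable from compound 1 to compound 2, is itself unreadable, so its size gives no guide. What is known is only that compound 2 sits at the limit, and nothing shown points to a readable step in either direction from there. Compound 3 is therefore expected to give about 40000 nM, within 15000 nM to 200000 nM, most probably reported again as a limit. The expected step that the limit leaves unreadable from compound 2 to compound 3 is thus estimated to be none beyond the scatter.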

Compound 3, half-maximal effective concentration: > 25000 nM
Compound 3: only a limit was reported; the forecaster's own chance of this, stated with the estimate: 85%; the middle value is on the limit's open side.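

In this assay compound 3 gives > 25000 nM as a limit of the assay. Among these compounds, no step among compound 1, compound 2 and compound 3 can therefore be read in size or direction: the limit of > 25000 nM in this assay, at which 3 of the 3 values shown sit. The compounds shown leave open whether any amide cap on the shared core gives a value within the range of the assay.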